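The source may report more compounds than this note shows. Statements on the series, on what has been measured and on what is new or still open speak of the compounds shown alone.

Compound 2 `N#CCCn1cnc2c(Br)c(Br)c(Br)c(Br)c21` gives 81% in a functional assay on MCF7 cells (Homo sapiens) for cytotoxicity, read by MTT assay, with a stated time of 24 h, tested at 10 uM (on this read-out higher numbers stand for a weaker effect at the one concentration tested and lower numbers for a stronger effect), the lower of the two numbers recorded so far. Compound 1 `Cc1nc2c(Br)c(Br)c(Br)c(Br)c2n1CCCCC#N` gives 109% in this assay, a higher number; these two compounds differ in more than one place, so their values are simply set side by side. Compound 3 `N#CCCCCn1cnc2c(Br)c(Br)c(Br)c(Br)c21` has not yet been tested in this assay; it differs from compound 2 by 2-cyanoethyl in place of cyano on a saturated chain carbon, two bonds along the chain from an aromatic nitrogen. Among the compounds with values here, with no measured step to lean on, a modest move toward a weaker effect is expected, as a number 11 percentage points higher from compound 2 to compound 3 (beyond the scatter). Compound 3 is therefore estimated at 92%, somewhere between 72% and 112%.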

Compound 3, a percentage reported as activity, at one concentration (the size of the read-out at that concentration, not a potency): 102%
For compound 3 the middle estimate is 10 percentage points below the measured one; the range from low to high includes it.
By their numbers in this assay, from the lowest: compound 2; then compounds 3 and 1 (each within the scatter of the next).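

In this assay the chain position is sensitive to length: 2-cyanoethyl in place of cyano gives a number 21 percentage points higher from compound 2 to compound 3 (beyond the scatter) and so a weaker effect. Hydrogen in place of methyl on an aromatic carbon gives a number 7 percentage points lower from compound 1 to compound 3 (within the scatter) and so no clear change, which means that this methyl makes no visible difference on the longer chain. Nothing measured here explains either step. Still open, as far as these compounds go, is whether a chain of intermediate length would sit closer to compound 2, and whether an amine or a carboxylic acid at the chain end, in place of the nitrile, would keep its stronger effect.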